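Swapping one branched side chain for another

The source may hold more compounds than are shown below. What is called first, only, known or untested is meant among the compounds shown, and "the series" means these compounds.

Compound 1 `CCCCC(O)C/C=C/[C@H]1[C@H](O)CC(=O)[C@@H]1CCCCCCC(=O)OC` gives 0.0054 mg/kg in a functional assay on the whole organism (strain Mongrel) for inhibition, with Canis familiaris (Canis lupus familiaris) as the target; a higher number here means that more compound is needed for the effect, a lower number that less compound is needed
Compound 2 `CCCCC(O)C(C)(C)/C=C/[C@H]1[C@H](O)CC(=O)[C@@H]1CCCCCCC(=O)OC` gives 0.14 mg/kg in this assay

Compound 2 has the higher of these two numbers, so more of it is needed for the effect. Compound 3 `CCCCC(O)(CC)C/C=C/[C@H]1[C@H](O)CC(=O)[C@@H]1CCCCCCC(=O)OC` carries 2-ethyl-2-hydroxyhexyl in place of 2-hydroxy-1,1-dimethylhexyl (2-ethyl-2-hydroxyhexyl in place of 2-hydroxy-1,1-dimethylhexyl on a double-bonded chain carbon bound to a double-bonded chain carbon). Within the data shown here, one measured step bears on this: putting 2-hydroxy-1,1-dimethylhexyl in place of 2-hydroxyhexyl gave a large change (a 26-fold higher number from compound 1 to compound 2 (1.41 log units; beyond the scatter)). Compound 3 loses that group but has a branch of its own, untested so far. A clear fall in this assay is therefore expected (a 12-fold lower number from compound 2 to compound 3 (1.07 log units; beyond the scatter)). Compound 3 is estimated at 0.012 mg/kg with 0.003 mg/kg to 0.06 mg/kg as the expected range.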

Compound 3, dose for 50% inhibition: 0.0278 mg/kg
Beside the measured number, compound 3's estimate is 2.3-fold (0.36 log units) below it; low and high end bracket the measured number.
By their numbers in this assay, from the lowest: compound 1; then compound 3; then compound 2.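

The same atoms arranged differently do not behave alike in this assay: 2-ethyl-2-hydroxyhexyl in place of 2-hydroxy-1,1-dimethylhexyl gives a 5.0-fold lower number from compound 2 to compound 3 (0.70 log units; beyond the scatter). Yet ethyl in place of hydrogen on the saturated chain carbon bound to the oxygen still gives a 5.1-fold higher number from compound 1 to compound 3 (0.71 log units; beyond the scatter), so each of the two branched chains needs a larger dose than 2-hydroxyhexyl. No measurement here explains why the two branched chains differ.

Still open, from the compounds shown here alone, is whether a single methyl in place of that ethyl would need a dose closer to that of the unbranched chain. Going by these compounds, a longer chain than hexyl also remains open.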